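A few compounds are considered here, and "the series" means these few. Any claim that something is new, unique, unknown or untested is made for them only; others in the source may bear on it.

The measured compounds:
compound 1, `Cc1cccc(N2CCN(c3cc(C(F)(F)F)ccc3CNC(=O)C(C)c3ccc(NS(C)(=O)=O)c(F)c3)CC2)c1`, 1.8 nM
compound 2, `CCCOc1cc(C(F)(F)F)ccc1CNC(=O)C(C)c1ccc(NS(C)(=O)=O)c(F)c1`, 2 nM
compound 3, `C[C@@H](C(=O)NCc1ccc(C(F)(F)F)cc1SC1CCCCC1)c1ccc(NS(C)(=O)=O)c(F)c1`, 13.9 nM

All three were tested in an assay on CHO cells for antagonist activity at transient receptor potential cation channel subfamily V member 1 (Homo sapiens), read by FLIPR; a lower number here means a stronger inhibitor, a higher number a weaker inhibitor. On these numbers compound 2 has the second highest of the three values; its gap to compound 1 lies within the scatter, so the two cannot be ranked, while compound 3 sits beyond the scatter above both. The unmeasured compound 4, `CC(C(=O)NCc1ccc(C(F)(F)F)cc1Cl)c1ccc(NS(C)(=O)=O)c(F)c1`, differs from compound 2 in one place: chloro in place of propoxy on an aromatic carbon. Among the compounds with values here, no step between measured compounds isolates this change, so the expectation rests on the spread among compounds 1, 2 and 3. The writer expects a modest step upward in this assay, probably just beyond the scatter. For compound 4 the estimate is 8 nM, within 2 nM to 30 nM. That estimate is expected to mean a step of a 4.0-fold higher number from compound 2 to compound 4 (0.60 log units; beyond the scatter).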

Compound 4, inhibition constant: 4 nM
For compound 4 the middle estimate is 2.0-fold (0.30 log units) above the measured one; the measured number falls inside the stated range.
By their numbers in this assay, from the lowest: compounds 1, 2 and 4 (each within the scatter of the next, the first and the last beyond it); then compound 3.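

In this assay chloro in place of propoxy on this aromatic carbon, ortho to a large group, gives a 2.0-fold higher number from compound 2 to compound 4 (0.30 log units; within the scatter) and so the two compounds cannot be ranked. The four heavy atoms of propoxy, with its hydrogen-bond acceptor, can thus give way to a single chlorine with no measurable loss in this read-out. Nothing measured here explains this result. Still open, on these data alone, is whether an amine, a nitrile or an alkoxy chain longer than propoxy at this position would keep the number in the same range.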